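A few compounds are considered here, and "the series" means these few. Any claim that something is new, unique, unknown or untested is made for them only; others in the source may bear on it.

The measured compounds are these:
compound 1, `Cc1ccc(-c2nnc(SCCCN3CCN(c4nc5ccccc5o4)CC3)o2)cc1`, which in a functional assay on HepG2 cells (Homo sapiens) for inhibition, read by MTT assay, with a stated time of 72 h (a lower number here means a stronger inhibitor, a higher number a weaker inhibitor), gives 154000 nM;
compound 2, `Clc1ccc(-c2nnc(SCCCN3CCN(c4nc5ccccc5o4)CC3)o2)cc1`, which gives 121000 nM;
compound 3, `Fc1ccc(-c2nnc(SCCCN3CCN(c4nc5ccccc5o4)CC3)o2)cc1`, which gives 83800 nM.

All three share one core and differ only in the group on an aromatic carbon of the outer six-membered aromatic ring of carbon only. Compound 3 holds the lowest of the three numbers, but the steps of a 1.4-fold lower number from compound 2 to compound 3 (0.16 log units; within the scatter) and a 1.8-fold lower number from compound 1 to compound 3 (0.26 log units; within the scatter) both sit within the scatter, so no order among the three can be read from them. The step between compound 1 and compound 2 a 1.3-fold lower number from compound 1 to compound 2 (0.10 log units; within the scatter) is likewise within the scatter.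

Compound 4, `CC(C)(C)Oc1ccc(-c2nnc(SCCCN3CCN(c4nc5ccccc5o4)CC3)o2)cc1`, carries the next change at that same aromatic carbon: tert-butoxy in place of fluoro on an aromatic carbon. The three measured steps all concern that one position, and none moved the number beyond the scatter. Compound 4 is therefore expected to land near compound 3, with the step of a 1.0-fold higher number from compound 3 to compound 4 (0.01 log units; within the scatter) expected to stay within the scatter. Compound 4 is estimated at 85000 nM, with a range from 30000 nM to 250000 nM.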

Compound 4, half-maximal inhibitory concentration: 121000 nM
Compound 4: the middle estimate sits 1.4-fold (0.15 log units) below what was measured; the range from low to high includes it.
By their numbers in this assay, from the lowest: compounds 3, 2, 4 and 1 (each within the scatter of the next).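

In this assay, replacing the single fluorine atom with tert-butoxy, a group of 5 heavy atoms that brings 1 hydrogen-bond acceptor, gives a 1.4-fold higher number from compound 3 to compound 4 (0.16 log units; within the scatter). The comparisons with the other two groups read the same way, with no change at the digits printed from compound 2 to compound 4 (within the scatter) and a 1.3-fold lower number from compound 1 to compound 4 (0.10 log units; within the scatter). The earlier compounds covered only methyl, chloro and fluoro, whereas compound 4 extends the set at this aromatic carbon, para to a large group, to a much larger oxygen-linked group, and still none of the four compounds is separated from another by a step beyond the scatter; nothing available explains this result.

What the four compounds leave open is whether any group at this position can move the number beyond the scatter, for instance an amine or a carboxylic acid, which carry a hydrogen-bond donor that none of the groups shown has. They also leave open whether a change elsewhere in the shared core, away from this aromatic carbon, would do so.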